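Two Swaps at Once: Estimating Compound 4

A few compounds are considered here, and "the series" means these few. Any claim that something is new, unique, unknown or untested is made for them only; others in the source may bear on it.

Compound 2 `CN(C)c1ccc(C(=O)N2CCC(n3cncc3-c3ccc(OS(=O)(=O)c4cccc5cnccc45)cc3)CC2)cc1` is the anchor of this small set; in an assay on HEK293 cells for antagonist activity at P2X purinoceptor 7 (Homo sapiens), read by fluorescence, with a stated time of 2 h (a lower number here means a stronger inhibitor, a higher number a weaker inhibitor), compound 2 gives 0.11 nM. Compound 1 `COc1ccc(C(=O)N2CCC(n3cncc3-c3ccc(OS(=O)(=O)c4cccc5cnccc45)cc3)CC2)cc1` differs from it by methoxy in place of dimethylamino on an aromatic carbon, and the measured change is a 700-fold higher number from compound 2 to compound 1 (2.85 log units; beyond the scatter). Compound 3 `CN(C)c1ccc(C(=O)N2CCC(n3cncc3-c3ccc(OS(=O)(=O)c4cccc(C#N)c4)cc3)CC2)cc1` differs from compound 2 elsewhere, by 3-cyanophenyl in place of isoquinolin-5-yl on a sulfonyl sulfur, and here the change is a 290-fold higher number from compound 2 to compound 3 (2.46 log units; beyond the scatter). In this assay compound 1 gives 77 nM and compound 3 gives 32 nM. Compound 4 `COc1ccc(C(=O)N2CCC(n3cncc3-c3ccc(OS(=O)(=O)c4cccc(C#N)c4)cc3)CC2)cc1` has not been measured; it differs from compound 3 by methoxy in place of dimethylamino on an aromatic carbon, the same change as from compound 2 to compound 1, with the place described in the same words. If this change acts alike on the core of compound 3, the expected step is a 310-fold higher number from compound 3 to compound 4 (2.49 log units; beyond the scatter), resting on a 700-fold higher number from compound 2 to compound 1 (2.85 log units; beyond the scatter), though a single earlier example leaves the size uncertain. Compound 4 is therefore estimated at 10000 nM, expected to fall between 2000 nM and 50000 nM.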

Compound 4, half-maximal inhibitory concentration: 312 nM
Compound 4: the middle estimate sits 32-fold (1.51 log units) above what was measured; measured number outside the range, below it.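

In this assay, methoxy in place of dimethylamino gives a 9.8-fold higher number from compound 3 to compound 4 (0.99 log units; beyond the scatter), so the direction of the step carries over to the core of compound 3, but its size does not: the same change on two cores in this assay, a 700-fold higher number (2.85 log units; beyond the scatter) from compound 2 to compound 1 and a 9.8-fold higher number (0.99 log units; beyond the scatter) from compound 3 to compound 4, 72-fold (1.86 log units) apart, beyond the scatter of two such steps

Read the other way, 3-cyanophenyl in place of isoquinolin-5-yl gives a 4.1-fold higher number from compound 1 to compound 4 (0.61 log units; beyond the scatter), so the two changes do not simply add up: the same change on two cores in this assay, a 290-fold higher number (2.46 log units; beyond the scatter) from compound 2 to compound 3 and a 4.1-fold higher number (0.61 log units; beyond the scatter) from compound 1 to compound 4, 72-fold (1.86 log units) apart, beyond the scatter of two such steps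

The size of each step therefore depends on what sits at the other place, but two cores cannot show why, or what step a third core would give.

The compounds shown leave open whether a primary amine or diethylamino on that aromatic carbon would behave like dimethylamino or like methoxy. They also leave open which of the two step sizes a plain phenyl on the sulfonyl sulfur would follow.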